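Acetyl to octylcarbonyl on the core of compound 1

The source may report more compounds than this note shows. Statements on the series, on what has been measured and on what is new or still open speak of the compounds shown alone.

Compound 1 `CC(=O)N1c2ccccc2CCC1C(=O)Nc1cc(C(F)(F)F)cc(C(F)(F)F)c1` is the acetyl member of this short set. As far as these compounds go, in a functional assay on NCI-H23 cells (Homo sapiens) for cytotoxicity, read by sulforhodamine B assay, with a stated time of 72 h (on this read-out higher numbers stand for weaker inhibition of growth and lower numbers for stronger inhibition of growth), compound 1 gives only a limit, > 70000 nM, so where it stands on the scale remains open; the evidence for it is simply (the limit of > 70000 nM in this assay, at which 1 of the 2 values shown sits). Within the data shown here, compound 2 `O=C(Nc1ccccc1C(F)(F)F)C1CCc2ccccc2N1`, which lacks the acetyl and carries a single trifluoromethyl on the anilide, gives 56800 nM in this assay; no step between compound 1 and compound 2 is defined, so the two readings merely stand side by side. Compound 3 `CCCCCCCCC(=O)N1c2ccccc2CCC1C(=O)Nc1cc(C(F)(F)F)cc(C(F)(F)F)c1` is not yet measured and differs from compound 1 by heptyl in place of hydrogen on a saturated chain carbon bound to a carbonyl carbon. Among the measured compounds shown here, with compound 1 at a limit, no measured step anchors the expectation, and the size of the change in this assay is an estimate only. The step from compound 1 to compound 3 is expected to be an at least 1.5-fold lower number from compound 1 to compound 3 (0.19 log units; that floor lies within the scatter), a small gain at most, quite possibly nothing beyond the scatter. Compound 3 is therefore estimated at 45000 nM, within a range from 15000 nM to 100000 nM.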

Compound 3, concentration for 50% growth inhibition: 3230 nM
Beside the measured number, compound 3's estimate is 14-fold (1.14 log units) above it; the measured number lies below the stated range.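

In this assay, among these compounds, the change from acetyl to octylcarbonyl on the core of compound 1 gives an at least 21-fold lower number from compound 1 to compound 3 (1.33 log units; beyond the scatter) and is the first readable effect at this position in the set. On a saturated chain carbon bound to a carbonyl carbon, heptyl in place of hydrogen is therefore tolerated, and it goes with stronger inhibition of growth. Compound 1 stands at a limit, so this step has a floor and no fixed size: (the limit of > 70000 nM in this assay, at which 1 of the 3 values shown sits).

With only acetyl and octylcarbonyl shown, the course of the effect with chain length stays open; butanoyl, a longer chain such as dodecanoyl, or an octyl chain ending in an amine or a carboxylic acid would bear on it. Compound 2 differs from compound 1 in more than one place and gives no reading on this position.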